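Diethylamino to (2-methoxyethyl)amino on the shared core

A few compounds are considered here, and "the series" means these few. Any claim that something is new, unique, unknown or untested is made for them only; others in the source may bear on it.

Two compounds in the series have numbers in an in vitro assay on 293-EBNA cells for binding affinity to corticotropin-releasing factor receptor 1 (Homo sapiens); a lower number here means a stronger inhibitor, a higher number a weaker inhibitor. Compound 1 `CCC(CO)Nc1nc(C)nc2c1nnn2-c1ccc(C(C)C)cc1Br` gives 25.3 nM in this assay. Compound 2 `CCN(CC)c1nc(C)nc2c1ncn2-c1ccc(C(C)C)cc1Br` gives 12.4 nM in this assay, the lowest of the two numbers; the gap to compound 1 lies beyond the scatter. Compound 1 and compound 2 differ in more than one place, so their two values are reported side by side and nothing further is read from them.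

Compound 3 `COCCNc1nc(C)nc2c1ncn2-c1ccc(C(C)C)cc1Br` is not yet measured. It differs from compound 2 in one place: (2-methoxyethyl)amino in place of diethylamino on an aromatic carbon. Within the data shown here, no single-change step between measured compounds exists, so the size of this change is a judgement. The replacement of a dialkylamino group by a monoalkylamino group on the shared core is expected to raise the number moderately, beyond the scatter, giving a 2.8-fold higher number from compound 2 to compound 3 (0.45 log units; beyond the scatter). Compound 3 is therefore estimated at 35 nM in this assay, within a range of 12 nM to 100 nM.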

Compound 3, inhibition constant: 210 nM
Compound 3: middle estimate off by 6.0-fold (0.78 log units), on the low side; the measured number lies above the stated range.
By their numbers in this assay, from the lowest: compound 2; then compound 1; then compound 3.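

Among these compounds, this is the first single-change step. In this assay, (2-methoxyethyl)amino in place of diethylamino on an aromatic carbon, next to the ring nitrogen, gives a 17-fold higher number from compound 2 to compound 3 (1.23 log units; beyond the scatter), although both groups count 5 heavy atoms, so this position responds strongly to an exchange at equal heavy-atom count. Among the compounds shown here, nothing measured so far speaks to the origin of this step.

The step combines the loss of one ethyl chain on the amine nitrogen with the arrival of a methoxy oxygen, and the compounds shown do not separate these two changes. Ethylamino or bis(2-methoxyethyl)amino on the shared core would tell them apart, and whether the hydrogen on the amine nitrogen or the ether oxygen carries the step remains open.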